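The compounds below may be only part of what the source reports. "The series", "measured", "known", "first", "only" and "open" are said of these compounds alone.

The compounds here share one core, a cyclic ketone carrying two benzylidene arms, and differ only in the substituent on one of the aromatic rings. Compound 1 `O=C1/C(=C/c2ccccc2)CCC/C1=C\c1ccccc1Cl` carries a 2-chlorophenyl group, compound 3 `O=C1/C(=C/c2ccccc2)CCC/C1=C\c1ccccc1Br` a 2-bromophenyl group, and compound 2 `O=C1/C(=C/c2ccccc2)CCC/C1=C\c1ccc(O)c(O)c1` a 3,4-dihydroxyphenyl group. All were examined in an assay on isolated protein for inhibition of Alpha glucosidase (Homo sapiens), with stated times of 5 min and 15 min; a lower number here means a stronger inhibitor, a higher number a weaker inhibitor. For compound 1 the entry in this assay is "not determined" (no result reported). For compound 3 the entry in this assay is "not determined" (no result reported), so compound 3 stands without a number of its own. The only measured reference point in the set is compound 2, which in this assay gives 20300 nM. The next compound, compound 4 `O=C1/C(=C/c2ccccc2)CCC/C1=C\c1cccc(O)c1`, is reached from compound 3 by one change (3-hydroxyphenyl in place of 2-bromophenyl on a double-bonded chain carbon bound to a double-bonded ring carbon). Since compound 3 has no value, no measured step can be computed, and the expectation for compound 4 rests on the single number shown for compound 2. Compound 4 carries only one of the two hydroxyl groups present in compound 2, so a value in the same weak region, or somewhat weaker, is expected. For compound 4 in this assay the estimated value is 45000 nM, with an expected range from 12000 nM to 200000 nM, because compound 2 gives 20300 nM and compound 4 is its closest structural neighbour in the set.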

Compound 4, half-maximal inhibitory concentration: 28400 nM
Beside the measured number, compound 4's estimate is 1.6-fold (0.20 log units) above it; the range from low to high includes it.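

In this assay, among the compounds shown here, putting hydrogen in place of hydroxy on an aromatic carbon gives a 1.4-fold higher number from compound 2 to compound 4 (0.15 log units; within the scatter), the first comparison between two measured compounds in this set. The two compounds cannot be told apart by this result, so the hydroxy group lost in that step shows no measurable contribution to inhibition, and one hydroxy group on this aromatic ring serves as well as two. No measurement among those shown accounts for this result.

As far as these compounds go, the change from 2-bromophenyl to 3-hydroxyphenyl cannot be read, as compound 3 has no value, so it remains open whether the remaining hydroxy group does better than a halogen at this place on a double-bonded chain carbon bound to a double-bonded ring carbon. Also open, from the compounds shown here alone, is whether that hydroxy group matters at all, which a plain phenyl group at the same place would test, and whether a methoxy group, an amine or a carboxylic acid on this ring would move the number beyond the scatter.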